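Carbamoyl for Benzyl Ester in a Purine Dipeptide Series

This account rests on a few compounds, and the source may have more. Where it says the series, first, only, none or still open, it means among the compounds named here.

Among the compounds with values here, in a functional assay on the whole organism (Tail, strain ICR) with Mus musculus as the target, in the tail flick test, with a stated time of 150 min, at a dose of 25 umol/kg by the oral route (on this read-out lower numbers stand for a weaker effect and higher numbers for a stronger effect at the one dose given), compound 1 `O=C(CN(c1ncnc2c1ncn2C1CCCCO1)C1CC1)N[C@@H](CCC(=O)OCc1ccccc1)C(=O)OCc1ccccc1` gives 14.1%, the lowest of the two numbers known; the nearest is compound 2 `O=C(O)CC[C@H](NC(=O)CN(c1nc(Cl)nc2[nH]cnc12)C1CC1)C(=O)O`, which in this assay gives 29.5%, a gap beyond the usual scatter. Compound 3 `NC(=O)C[C@H](NC(=O)CN(c1ncnc2c1ncn2C1CCCCO1)C1CC1)C(=O)OCc1ccccc1` differs from compound 1 by carbamoyl in place of (benzyloxycarbonyl)methyl on a saturated chain carbon, two bonds along the chain from an amide-type nitrogen and a carbonyl carbon. Within the data shown here, no measured pair shows this exact change, so the size of the step is open; a modest rise is expected, a number 5.9 percentage points higher from compound 1 to compound 3 (within the scatter), possibly within the scatter. In this assay compound 3 is estimated at 20%, with a range from 6% to 38%.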

Compound 3, a percentage reported as activity, at one dose (the size of the read-out at that dose, not a potency): 21.7%
For compound 3 the middle estimate is 1.7 percentage points below the measured one; the measured number falls inside the stated range.
By their numbers in this assay, from the lowest: compounds 1, 3 and 2 (each within the scatter of the next, the first and the last beyond it).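

In this assay, carbamoyl in place of (benzyloxycarbonyl)methyl on this saturated chain carbon gives a number 7.6 percentage points higher from compound 1 to compound 3 (within the scatter). The position therefore gives up its six-membered aromatic ring of carbon only and most of its heavy atoms with no change beyond the scatter of this read-out. Nothing available here accounts for this result. On these data alone, whether an amine or a longer chain ending in carbamoyl at this carbon would give a different read-out remains open. So does the effect of the same change with the remaining benzyl ester replaced by a carboxylic acid.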